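The source may hold more compounds than are shown below. What is called first, only, known or untested is meant among the compounds shown, and "the series" means these compounds.

Of the compounds shown here, three of one shared core have been measured in a functional assay (trachea) with Cavia porcellus as the target; a higher number here means a weaker inhibitor, a lower number a stronger inhibitor. Compound 1 `CCCCn1nc(-c2cccnc2)c2ccccc2c1=O` gives 2290 nM. Compound 2 `CC(C)=CCn1nc(-c2cccnc2)c2ccccc2c1=O` gives 1380 nM. Compound 3 `O=c1c2ccccc2c(-c2cccnc2)nn1CCCCSc1ncccn1` gives 6170 nM. Among these, compound 2 has the lowest number, yet its neighbour is close: a 1.7-fold lower number from compound 1 to compound 2 (0.22 log units; within the scatter), so the two cannot be told apart. Within the data shown here, only compound 3 stands clearly apart: a 2.7-fold higher number from compound 1 to compound 3 (0.43 log units; beyond the scatter), the one step here that goes beyond the scatter, where a group with its own ring is attached at the far end of the chain.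

Compound 4 `O=C(O)CCCn1nc(-c2cccnc2)c2ccccc2c1=O` differs from compound 2 at the chain carried by the aromatic nitrogen: 2-carboxyethyl in place of 2-methylprop-1-en-1-yl on a saturated chain carbon bound to an aromatic nitrogen. The new chain ends in a carboxylic acid, which brings one hydrogen-bond donor and one hydrogen-bond acceptor where compound 2 had none.

Among the measured compounds shown here, no measured pair here exchanges a hydrocarbon chain for one bearing an acid, so the step from compound 1 to compound 3 is the nearest guide: it shows that enlarging and changing what the chain carries weakened inhibition modestly, while the step from compound 1 to compound 2 shows that a small change within a hydrocarbon chain barely matters. Taken together, a modest weakening is expected for compound 4: the estimate is a 2.9-fold higher number from compound 2 to compound 4 (0.46 log units; beyond the scatter), giving 4000 nM, with a range from 1500 nM to 12000 nM.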

Compound 4, half-maximal inhibitory concentration: > 100000 nM
Compound 4 ended at the assay's limit; the forecaster's own chance of this, stated with the estimate: 15%; middle value at least 25-fold (1.39 log units) away from the limit.
By their numbers in this assay, from the lowest: compounds 2 and 1 (each within the scatter of the next); then compound 3. At a limit, above all of these: compound 4.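

Compound 4 stands at a limit of this assay and not at an exact number: the limit of > 100000 nM in this assay, at which 1 of the 4 values shown sits.

Its steps are therefore floors, and each is large: an at least 72-fold higher number from compound 2 to compound 4 (1.86 log units; beyond the scatter), an at least 43-fold higher number from compound 1 to compound 4 (1.64 log units; beyond the scatter), and an at least 16-fold higher number from compound 3 to compound 4 (1.20 log units; beyond the scatter). The earlier compounds shown here showed that this chain can change from butyl to 3-methylbut-2-en-1-yl with no readable difference, and that even a pyrimidine-bearing end costs only a modest loss, whereas the swap of a methyl for a carboxy at the chain end in the pair of compound 1 and compound 4 shows that the identity of the end group can matter far more than any change seen before.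

From the compounds shown here alone, what remains open is whether the loss belongs to the carboxylic acid itself: an ester, an amide or an alcohol at the same chain end would help to separate the acid from other oxygen-bearing groups, and a longer chain ending in a carboxylic acid would test the distance from the core. Going by these compounds, how far compound 4 actually lies past the limit also remains unknown, and so the true size of all three steps stays open.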